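This account rests on a few compounds, and the source may have more. Where it says the series, first, only, none or still open, it means among the compounds named here.

Measured in a functional assay on A549 cells (Homo sapiens) for inhibition, read by MTT assay, with a stated time of 72 h; on this read-out higher numbers stand for weaker inhibition and lower numbers for stronger inhibition:
Compound 1 `C=C(c1ccc(OC)c(F)c1)C1COC(C)(C)OO1`: 100000 nM
Compound 2 `C=C(c1ccc(F)c(F)c1)C1COC2(CCCCC2)OO1`: 7880 nM

In this assay compound 2 gives 7880 nM, the lower of the two numbers, and its gap to compound 1 lies beyond the scatter. Compound 3 `C=C(c1ccc(OC)c(F)c1)C1COC2(CCCCC2)OO1`, not yet measured, has methoxy in place of fluoro on an aromatic carbon. Among the compounds with values here, no measured pair shows this change alone, so its size is uncertain. Compound 1, which also carries the methoxy, reads 100000 nM, so a modest move toward higher numbers is expected. The expected change is a 1.6-fold higher number from compound 2 to compound 3 (0.22 log units; within the scatter). For compound 3 the estimated value is 13000 nM, with an expected range of 4500 nM to 40000 nM.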

Compound 3, half-maximal inhibitory concentration: 6530 nM
Compound 3: the middle estimate sits 2.0-fold (0.30 log units) above what was measured; low and high end bracket the measured number.
By their numbers in this assay, from the lowest: compounds 3 and 2 (each within the scatter of the next); then compound 1.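

In this assay, the step of a 1.2-fold lower number from compound 2 to compound 3 (0.08 log units; within the scatter) for methoxy in place of fluoro shows that this aromatic carbon takes either group with no readable difference. Compound 1 also carries methoxy and reads 100000 nM, so methoxy here does not by itself bring such a high number. Nothing measured explains why the two groups read alike. Still open, on these data alone, is whether an amine, a carboxylic acid or a longer chain such as butoxy on this carbon would also leave the number unchanged.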